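Pyrrole series: cyclohexylamine analog, methyl for chlorophenyl

The compounds below may be only part of what the source reports. "The series", "measured", "known", "first", "only" and "open" are said of these compounds alone.

Compound 3 `Cc1c(CNC2CCCCC2)cc(-c2ccc(Cl)cc2)n1-c1ccc(Cl)cc1` has no single number in an ADME assay on RAW264.7 cells (Mus musculus) for cytotoxicity, read by trypan blue exclusion, with a stated time of 48 h; on this read-out lower numbers stand for stronger inhibition of growth and higher numbers for weaker inhibition of growth; its result is recorded as "not determined" (no result reported), so it gives no anchor of its own. Compound 4 `Cc1cc(CNC2CCCCC2)c(C)n1-c1ccc(Cl)cc1` differs from it by methyl in place of 4-chlorophenyl on an aromatic carbon. Among the compounds with values here, no measured step covers this change directly. Within the data shown here, the only measured step in the set, a 55-fold higher number from compound 1 to compound 2 (1.74 log units; beyond the scatter), concerns a different site: compound 1 `Cc1cc(CNCc2ccc(Cl)cc2)c(C)n1-c1ccc(Cl)cc1` gives 0.1 ug/mL in this assay, and compound 2 `Cc1cc(CNCc2ccccc2)c(C)n1-c1ccc(Cl)cc1` gives 5.5 ug/mL. Both of these carry the methyl that enters in compound 4, and neither is the cyclohexylamine; they bracket the range the methyl-bearing core has reached so far. With compound 3 unmeasured, no direction or size of step can be stated for the change to compound 4, and the expectation rests on compounds 1 and 2 alone. Compound 4 lacks the chlorine on the amine side that separates compound 1 from compound 2, so its value is expected to lie near that of compound 2, estimated at 5 ug/mL with a range from 1 ug/mL to 25 ug/mL.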

Compound 4, concentration for 50% growth inhibition: 10 ug/mL
The estimate for compound 4 lay 2.0-fold (0.30 log units) below the measured number; low and high end bracket the measured number.
By their numbers in this assay, from the lowest: compound 1; then compounds 2 and 4 (each within the scatter of the next).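

In this assay, cyclohexyl in place of benzyl on the amine nitrogen gives a step within the scatter (a 1.8-fold higher number from compound 2 to compound 4 (0.26 log units; within the scatter)), so the two amine substituents cannot be told apart here. Cyclohexyl in place of 4-chlorobenzyl gives a large step beyond the scatter (a 100-fold higher number from compound 1 to compound 4 (2.00 log units; beyond the scatter)), which leaves compound 1, the only compound shown with 4-chlorobenzyl, apart from compounds 2 and 4. No measured evidence bears on these results.

Going by these compounds, the step from compound 3 cannot be read, so the effect of methyl in place of 4-chlorophenyl on the aromatic carbon next to the ring nitrogen stays open. Also open, on these data alone, is how a piperidine at the amine position, or fluoro or methoxy in place of the chloro on the benzyl group, would read on the shared core.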